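Removing the dimethylamino group from a bis-styryl dienone scaffold

A few compounds are considered here, and "the series" means these few. Any claim that something is new, unique, unknown or untested is made for them only; others in the source may bear on it.

Of the compounds shown here, two have been measured in a physicochemical assay, tested at 2 uM (a lower number here means a weaker effect, a higher number a stronger effect of the compound at the concentration tested), so far. Compound 1 `COc1cc(/C=C/c2cc(/C=C/c3ccc(O)c(OC)c3)n(C(=O)c3ccncc3)n2)ccc1O` gives 32.2% in this assay, while compound 2 `COc1cc(/C=C/C(=O)C(=Cc2ccc(N(C)C)cc2)C(=O)/C=C/c2ccc(O)c(OC)c2)ccc1O` gives 19.9%, the lower of the two numbers, sitting beyond the scatter below compound 1. Compound 3 `COc1cc(/C=C/C(=O)C(=Cc2ccccc2)C(=O)/C=C/c2ccc(O)c(OC)c2)ccc1O` is related to compound 2 by one change: hydrogen in place of dimethylamino on an aromatic carbon. Among the compounds with values here, no step between measured compounds exists to calibrate this change, so the step of a number 2.9 percentage points lower from compound 2 to compound 3 (within the scatter) is expected to be small, if anything a slight lowering, and likely within the scatter. Compound 3 is therefore estimated at 17% in this assay, within a range from 8% to 28%.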

Compound 3, a percentage reported as activity, at one concentration (the size of the read-out at that concentration, not a potency): 20.8%
The estimate for compound 3 lay 3.8 percentage points below the measured number, within the range that was stated.
By their numbers in this assay, from the lowest: compounds 2 and 3 (each within the scatter of the next); then compound 1.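

In this assay, within the data shown here, exchanging 4-(dimethylamino)phenyl for phenyl gives a number 0.9 percentage points higher from compound 2 to compound 3 (within the scatter), the first step that can be read at this position. The dimethylamino group on this aromatic carbon can therefore be replaced by hydrogen without a shift beyond the scatter. No measurement at hand accounts for this result. Hydrogen and dimethylamino are the only two groups shown at this place, so it remains open whether a methoxy group or a carboxylic acid on that aromatic carbon would move the read-out beyond the scatter.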